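A few compounds are considered here, and "the series" means these few. Any claim that something is new, unique, unknown or untested is made for them only; others in the source may bear on it.

Working notes on the amide series, read in an ADME assay on microsomes from liver (Homo sapiens) for metabolic stability, read by LC-MS, with a stated time of 30 min, tested at 1 uM; on this read-out lower numbers stand for a less stable compound and higher numbers for a more stable compound. Compound 1 (`O=C(NCc1ccc(S(=O)(=O)c2ccccc2)cc1)c1nc2cnccc2[nH]1`) gives 73%, and compound 2 (`O=C(NCc1ccc(S(=O)(=O)c2ccccc2)cc1)c1cc2ccncc2s1`) gives 48%. Compound 3 (`O=C(NCc1ccc(S(=O)(=O)c2ccccc2)cc1)c1c[nH]c2ccncc12`) reads > 99%, which is a limit of the assay and not a number. Compound 3 therefore stands at the top of the three values, and its position rests on (the limit of > 99% in this assay, at which 1 of the 3 values shown sits).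

Compound 4 (`O=C(NCc1ccc(S(=O)(=O)c2ccccc2)cc1)c1ccc2nncn2c1`) changes only the group on the carbonyl carbon: a group of 9 heavy atoms (6 carbon, 3 nitrogen; one five-membered aromatic ring with 3 hetero atoms, one six-membered aromatic ring with 1 hetero atom) in place of a group of 9 heavy atoms (7 carbon, 2 nitrogen; one five-membered aromatic ring with 1 hetero atom, one six-membered aromatic ring with 1 hetero atom), on a carbonyl carbon. The three measured steps swap the group at this same place. They show that this place matters in this assay, with a number 25 percentage points lower from compound 1 to compound 2 (beyond the scatter) and a number at least 51 percentage points higher from compound 2 to compound 3 (beyond the scatter).

The closest guide is compound 1, whose group also holds 6 carbon and 3 nitrogen. Its relation to compound 3 is a number at least 26 percentage points higher from compound 1 to compound 3 (beyond the scatter). A fall of similar size is therefore expected here, modest and beyond the scatter, though the ring differs and a result near the limit remains possible. The expected step is a number at least 24 percentage points lower from compound 3 to compound 4 (beyond the scatter). For compound 4 the estimated value is 75%, with an expected range from 50% to 97%.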

Compound 4, percent of the compound remaining: 96%
For compound 4 the middle estimate is 21 percentage points below the measured one, and the stated range covers the measured number.
By their numbers in this assay, from the lowest: compound 2; then compound 1; then compound 4. At a limit, above all of these: compound 3.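

In this assay, the group on the carbonyl carbon with 3 hetero atoms in its five-membered aromatic ring gives a high reading, with a number 48 percentage points higher from compound 2 to compound 4 (beyond the scatter) and a number 23 percentage points higher from compound 1 to compound 4 (beyond the scatter); compound 1 and compound 4 have the same count of 6 carbon and 3 nitrogen in this group, so that count alone does not set the reading. The group of compound 3 has 1 hydrogen-bond donor and the group of compound 4 has 0, which shows that a high reading at this place does not require a donor in the group. From the compounds shown here alone, the remaining comparison reads only as a number at least 3 percentage points lower from compound 3 to compound 4 (that floor lies within the scatter), and its true size stays unknown because the reading of compound 3 is a limit of the assay: the limit of > 99% in this assay, at which 1 of the 4 values shown sits.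

The compounds shown leave open how a single-ring group such as morpholine, or a carboxylic acid on the fused rings, would read at this carbonyl carbon. They also leave open whether the high readings of compound 3 and compound 4 hold when the rest of the molecule changes, since all four compounds share it.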